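Furan to thiophene on the aryl ether of an imidazoline

The source may hold more compounds than are shown below. What is called first, only, known or untested is meant among the compounds shown, and "the series" means these compounds.

Going by the values given here, compound 2 `c1coc(-c2ccccc2OCC2=NCCN2)c1` stands highest of the two numbers measured so far: in a functional assay with Alpha-1A adrenergic receptor (Homo sapiens) as the target, read by calcium flux (on this read-out higher numbers stand for larger maximal responses and lower numbers for smaller maximal responses), compound 2 gives 106%. Its nearest neighbour is compound 1 `c1cnc(-c2ccccc2OCC2=NCCN2)nc1`, which in this assay gives 90%; the change of furan-2-yl in place of pyrimidin-2-yl on an aromatic carbon brought a number 16 percentage points higher from compound 1 to compound 2 (beyond the scatter), a modest step beyond the scatter. Compound 3 `c1csc(-c2ccccc2OCC2=NCCN2)c1` differs from compound 2 as follows: thiophen-2-yl in place of furan-2-yl on an aromatic carbon. Among the compounds with values here, no measured step concerns this exchange of one five-membered aromatic ring for another; the only step known, from compound 1 to compound 2, exchanged a six-membered for a five-membered ring and was modest. The account therefore expects no step beyond the scatter in this assay for compound 3. In this assay compound 3 is expected to reach 102%, with a range from 82% to 122%. This estimate means an expected step of a number 4 percentage points lower from compound 2 to compound 3 (within the scatter), within the scatter.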

Compound 3, largest response reached (reported as maximum), in percent of the reference or control that the assay uses: 101%
The estimate for compound 3 lay 1 percentage points above the measured number; measured number inside the range.
By their numbers in this assay, from the lowest: compound 1; then compounds 3 and 2 (each within the scatter of the next).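

In this assay, thiophen-2-yl in place of furan-2-yl gives a number 5 percentage points lower from compound 2 to compound 3 (within the scatter), so at this place on the aromatic ring, the exchange of oxygen for sulfur in a five-membered aromatic ring with 1 hetero atom does not separate the two compounds. Against pyrimidin-2-yl, the thiophene gives a number 11 percentage points higher from compound 1 to compound 3 (beyond the scatter), so in this assay both five-membered rings now stand apart from the six-membered ring of compound 1, a pattern that holds for all three compounds shown. Nothing available bears on the reason for this result.

As far as these compounds go, it remains open how a plain phenyl ring, a pyridin-2-yl ring or a methyl group would read at the same place. From the compounds shown here alone, it is also open whether a methyl or a chloro group on the thiophene ring would keep compound 3 within the scatter of compound 2.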